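Removing the methoxy from compound 2: expected potency of compound 3

The source may hold more compounds than are shown below. What is called first, only, known or untested is meant among the compounds shown, and "the series" means these compounds.

Within the data shown here, the series so far holds two measured members. Compound 1 `Cc1[nH]c2ccccc2c1C1=C(Br)C(=O)C(Br)=C(c2c(C)[nH]c3ccccc23)C1=O` gives 8.33 ug/mL in a functional assay on MCF7 cells (Homo sapiens) for antiproliferative activity, read by CCK-8 assay, with a stated time of 48 h; a higher number here means a weaker inhibitor, a lower number a stronger inhibitor. Compound 2 `COc1ccc2[nH]c(C)c(C3=C(Br)C(=O)C(Br)=C(c4c(-c5ccccc5)[nH]c5ccccc45)C3=O)c2c1` gives 3.38 ug/mL in the same assay, the lower of the two numbers; compound 1 sits higher by a margin beyond the usual scatter, so compound 2 is the stronger inhibitor of the pair.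

Compound 3 `Cc1[nH]c2ccccc2c1C1=C(Br)C(=O)C(Br)=C(c2c(-c3ccccc3)[nH]c3ccccc23)C1=O` is still to be measured. It differs from compound 2 in one place: hydrogen in place of methoxy on an aromatic carbon. Among the measured compounds shown here, no pair among the measured compounds isolates this change, since compound 1 and compound 2 differ at two sites at once, so the weight of the methoxy alone cannot be read from the present numbers.

With no direct comparison available, the step from compound 2 to compound 3 is expected to be small, at most modest, and if anything toward a higher number. For compound 3 the estimate in this assay is 4.5 ug/mL, with a range from 2 ug/mL to 10 ug/mL, and this corresponds to the expected step of a 1.3-fold higher number from compound 2 to compound 3 (0.12 log units; within the scatter).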

Compound 3, half-maximal inhibitory concentration: 3.02 ug/mL
The estimate for compound 3 lay 1.5-fold (0.17 log units) above the measured number; measured number inside the range.
By their numbers in this assay, from the lowest: compounds 3 and 2 (each within the scatter of the next); then compound 1.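

In this assay, hydrogen in place of methoxy on an aromatic carbon gives a 1.1-fold lower number from compound 2 to compound 3 (0.05 log units; within the scatter), so at this site of the six-membered aromatic ring, the 5-methoxy-2-methyl-1H-indol-3-yl and 2-methyl-1H-indol-3-yl groups cannot be told apart in this assay. The same compound separates the two changes that were combined between compound 1 and compound 2: phenyl in place of methyl on an aromatic carbon gives a 2.8-fold lower number from compound 1 to compound 3 (0.44 log units; beyond the scatter), so of the two single-site steps now available, only the phenyl change lies beyond the scatter. No supporting data bear on why the methoxy change leaves the number within the scatter or why the phenyl change moves it.

As far as these compounds go, the methoxy conclusion rests on a single pair, so it remains open whether an amine, a carboxylic acid or a longer chain such as butoxy on the same aromatic carbon would also stay within the scatter. From the compounds shown here alone, the phenyl step is likewise a single comparison, and it remains open how an ethyl or benzyl group at that carbon would read, or whether chlorine in place of bromine on the shared core would shift the number.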